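The source may hold more compounds than are shown below. What is called first, only, known or untested is meant among the compounds shown, and "the series" means these compounds.

Series notes, measured in a functional assay on K562 cells (Homo sapiens) for antiproliferative activity, with a stated time of 48 h; a lower number here means that less compound is needed, a higher number that more compound is needed for the effect:

- compound 1 `O=C(CCCCCCC(=O)Nc1ccc(C(F)(F)F)cc1)NO`: 2100 nM
- compound 2 `O=C(CCCCCCC(=O)Nc1ccc(Cl)cc1)NO`: 3300 nM
- compound 3 `O=C(CCCCCCC(=O)Nc1cccc(Cl)c1)NO`: 3500 nM

Compound 1 is the reference point here. Compound 2 and compound 3 both lie within the scatter of it, so the three numbers do not yet separate the substituents in this assay.

The next compound is compound 4 `O=C(CCCCCCC(=O)Nc1ccc(I)cc1)NO`, which is still to be measured. Relative to compound 1 the change is iodo in place of trifluoromethyl on an aromatic carbon, para to a large group.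

For the measured compounds named here, one measured step bears directly on this change, a 1.6-fold higher number from compound 1 to compound 2 (0.20 log units; within the scatter), with chloro in place of trifluoromethyl on an aromatic carbon. That step stays within the scatter. Compound 3, also a chloro compound, gives 3500 nM, which adds no sign of a larger effect. Going by the values given here, no iodo compound has been measured, so the halogen comparison is an extrapolation from chloro alone.

No step beyond the scatter is therefore expected in this assay. The expected change is a 1.3-fold higher number from compound 1 to compound 4 (0.12 log units; within the scatter), which would not be a real difference. For compound 4 the estimated value is 2800 nM, with an expected range of 1300 nM to 6000 nM.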

Compound 4, half-maximal effective concentration: 1300 nM
For compound 4 the middle estimate is 2.2-fold (0.33 log units) above the measured one; measured number inside the range.
By their numbers in this assay, from the lowest: compounds 4, 1, 2 and 3 (each within the scatter of the next, the first and the last beyond it).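

In this assay, the aromatic carbon para to a large group now gives a step beyond the scatter: a 2.5-fold lower number from compound 2 to compound 4 (0.40 log units; beyond the scatter), with iodo in place of chloro. For the compounds shown here, the size is modest, but this shows that the choice of halogen at this position can register in the read-out, which the earlier compounds did not show. By contrast, with iodo in place of trifluoromethyl, the step is a 1.6-fold lower number from compound 1 to compound 4 (0.21 log units; within the scatter), so these two groups remain unseparated even though 1 heavy atom replaces 4 heavy atoms, and the series offers no measured basis for explaining the gap between the iodo and chloro compounds.

The compounds shown leave open where bromo would fall at this position relative to chloro and iodo, and whether a methoxy group or an amine there would stay within the scatter of compound 1. They also leave open whether iodo at the position held by chloro in compound 3, or a longer chain in the shared core, would change the read-out.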